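A Small Chain Change from Compound 3 to Compound 4

A few compounds are considered here, and "the series" means these few. Any claim that something is new, unique, unknown or untested is made for them only; others in the source may bear on it.

Three small molecules have been tested in a functional assay on MDA-MB-231 cells (Homo sapiens) for cytotoxicity, read by sulforhodamine B assay, with a stated time of 72 h; a higher number here means a weaker inhibitor, a lower number a stronger inhibitor. Compound 1 `Brc1cccc(OCCCCn2ccnc2)c1` gives 27500 nM, and compound 2 `Ic1ccc(OCCCCCn2ccnc2)cc1` gives 27400 nM. Compound 3 `c1ccc2sc(SCCCn3ccnc3)nc2c1` gives 55100 nM. Repeated measurements of this kind naturally vary, and the number for compound 3 lies within that scatter of both other numbers, so these data cannot rank the three compounds.

The next molecule is compound 4 `c1ccc2sc(SCCCCn3ccnc3)nc2c1`. It has (1H-imidazol-1-yl)methyl in place of 1H-imidazol-1-yl on a saturated chain carbon, three bonds along the chain from a sulfur. The rest of the structure stays the same.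

Among the measured compounds shown here, no two measured compounds differ in only one place, so no measured step can serve as a direct guide. The only clue is indirect. Compound 1 at 27500 nM and compound 2 at 27400 nM are structurally further from compound 3 than compound 4 is, yet their values remain within the scatter of compound 3. The expected change is therefore small, with no step beyond the scatter and no reliable direction: a 1.4-fold lower number from compound 3 to compound 4 (0.14 log units; within the scatter). In this assay, the estimate for compound 4 is 40000 nM, with an expected range of 18000 nM to 85000 nM.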

Compound 4, half-maximal inhibitory concentration: 55100 nM
Compound 4: middle estimate off by 1.4-fold (0.14 log units), on the low side, and the stated range covers the measured number.
By their numbers in this assay, from the lowest: compounds 2, 1, 3 and 4 (each within the scatter of the next).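

Among the compounds shown here, this is the first pair here that differs in only one place, so it gives the first direct reading of a single change rather than an indirect clue from more distant structures. Putting (1H-imidazol-1-yl)methyl in place of 1H-imidazol-1-yl on a saturated chain carbon, three bonds along the chain from a sulfur, gives no change at the digits printed from compound 3 to compound 4 (within the scatter) in this assay and so shows that, for this one pair, the extra chain carbon leaves the read-out where it was. Nothing available here explains why the number holds still, and one pair cannot show whether the same change would behave alike on a different core.

The compounds shown stop at (1H-imidazol-1-yl)methyl, so it remains open whether a longer chain at this place would also leave the number unchanged or would finally move it beyond the scatter. Going by these compounds, it is equally open what would happen if an amine or a carboxylic acid took the place of 1H-imidazol-1-yl at the end of the chain.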